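The source may hold more compounds than are shown below. What is called first, only, known or untested is meant among the compounds shown, and "the series" means these compounds.

Measured compounds:
- compound 1, `CN(C)CCn1cnnc1-c1cc(Oc2ccc(NC(=O)Nc3ccc(F)c(Cl)c3)cc2F)ccn1`: 7580 nM
- compound 2, `CCN(CC)CCn1cnnc1-c1cc(Oc2ccc(NC(=O)Nc3cccc(C(F)(F)F)c3)cc2F)ccn1`: 6920 nM
- compound 3, `CCN(CC)CCn1cnnc1-c1cc(Oc2ccc(NC(=O)Nc3ccccc3C(F)(F)F)cc2F)ccn1`: 23500 nM

In an ADME assay on WI-38 cells (Homo sapiens) for cytotoxicity, read by MTT assay, with a stated time of 72 h (on this read-out lower numbers stand for stronger inhibition and higher numbers for weaker inhibition), compound 3 gives 23500 nM, the highest of the three numbers; compound 1 lies closest to it and compound 2 furthest, both beyond the scatter. Compound 4, `CCN(CC)CCn1cnnc1-c1cc(Oc2ccc(NC(=O)Nc3ccc(F)c(Cl)c3)cc2F)ccn1`, differs from compound 3 in one place: 3-chloro-4-fluorophenyl in place of 2-(trifluoromethyl)phenyl on an amide-type nitrogen. For the measured compounds named here, no measured pair shows this exact exchange. Going by the values given here, the only step within the set that touches the same position is a 3.4-fold higher number from compound 2 to compound 3 (0.53 log units; beyond the scatter), a positional change of the trifluoromethyl group. Compound 1 carries the same 3-chloro-4-fluorophenyl group that enters in compound 4, though it differs from compound 4 elsewhere in the shared core, and its value sits close to that of compound 2. Taken together, these point to compound 4 returning to the range of compounds 1 and 2, so a decrease beyond the scatter is expected, a 3.1-fold lower number from compound 3 to compound 4 (0.50 log units; beyond the scatter). Compound 4 is therefore estimated at 7500 nM, within a range of 3500 nM to 16000 nM.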

Compound 4, half-maximal inhibitory concentration: 28700 nM
Beside the measured number, compound 4's estimate is 3.8-fold (0.58 log units) below it, outside the stated range (above it).
By their numbers in this assay, from the lowest: compounds 2 and 1 (each within the scatter of the next); then compounds 3 and 4 (each within the scatter of the next).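

In this assay the exchange on the amide-type nitrogen gives a 1.2-fold higher number from compound 3 to compound 4 (0.09 log units; within the scatter) so 2-(trifluoromethyl)phenyl and 3-chloro-4-fluorophenyl are not told apart at this position. With diethylamino held constant, a 4.1-fold higher number from compound 2 to compound 4 (0.62 log units; beyond the scatter) sets 3-(trifluoromethyl)phenyl apart from 3-chloro-4-fluorophenyl as well as from 2-(trifluoromethyl)phenyl, so the lower number belongs to that one group among the three. The 3-chloro-4-fluorophenyl group does not fix the number by itself, since a 3.8-fold higher number from compound 1 to compound 4 (0.58 log units; beyond the scatter) comes with diethylamino in place of dimethylamino.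

Nothing shown gives a reason for any of these differences. Going by these compounds, it stays open whether dimethylamino would shift the number with 3-(trifluoromethyl)phenyl too, and how morpholine in place of diethylamino, or 3-cyanophenyl on the amide-type nitrogen, would read.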